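The source may hold more compounds than are shown below. What is called first, only, known or untested is meant among the compounds shown, and "the series" means these compounds.

Of the compounds shown here, two have so far been read in a physicochemical assay for solubility, with a stated time of 24 h, tested at 30 mg/mL (on this read-out higher numbers stand for higher solubility and lower numbers for lower solubility), and both carry numbers. Compound 1 (`CC(=O)N1CC(CC(=O)NO)(NS(=O)(=O)c2ccc(OCc3cc(C)nc4ccccc34)cc2)C1`) gives 800000 nM as its value, while compound 2 (`Cc1cc(COc2ccc(S(=O)(=O)NCCC(=O)NO)cc2)c2ccccc2n1`) gives 4100000 nM as its value, the higher of the two and beyond the scatter of compound 1. Compound 3 (`Cc1cc(COc2ccc(S(=O)(=O)NC3(CC(=O)NO)CC3)cc2)c2ccccc2n1`) is still unmeasured and differs from compound 2 in one place (a group of 8 heavy atoms (5 carbon, 1 nitrogen, 2 oxygen; one three-membered non-aromatic ring of carbon only) in place of a group of 6 heavy atoms (3 carbon, 1 nitrogen, 2 oxygen; no ring), on a sulfonamide nitrogen), where a group with a three-membered non-aromatic ring of carbon only replaces the 2-(hydroxycarbamoyl)ethyl on a sulfonamide nitrogen. Among the compounds with values here, no measured pair differing in one place offers a guide. Within the data shown here, the only hint is that compound 1 stands at 800000 nM against the higher number of compound 2. A downward step in this assay somewhat beyond the scatter is therefore expected, estimated as a 2.7-fold lower number from compound 2 to compound 3 (0.44 log units; beyond the scatter) in size. Compound 3 is expected at 1500000 nM with an estimated range from 500000 nM to 4500000 nM in this read-out.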

Compound 3, solubility: 1600000 nM
Compound 3: middle estimate off by 1.1-fold (0.03 log units), on the low side; low and high end bracket the measured number.
By their numbers in this assay, from the lowest: compounds 1 and 3 (each within the scatter of the next); then compound 2.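

In this assay the change on a sulfonamide nitrogen now has a reading of its own: the 2-(hydroxycarbamoyl)ethyl gives way to a group with a three-membered non-aromatic ring of carbon only, and the result is a 2.6-fold lower number from compound 2 to compound 3 (0.41 log units; beyond the scatter) for this single change. The counted hydrogen-bond donors and acceptors stay the same on both sides and neither group carries a net charge, while the heavy atom count and the ring differ. Nothing shown gives a reason for the step.

Going by these compounds, it remains open whether a four-membered carbon ring, or an amine on the same chain, would give a step of similar size. On these data alone, it is also open whether this step would hold on the core of compound 1.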